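The compounds below may be only part of what the source reports. "The series", "measured", "known", "first", "only" and "open" are said of these compounds alone.

Compound 3 `N#Cc1cccc(-c2c[nH]c3ncc(-c4cncnc4)cc23)c1` stands with compound 1 `Cn1cc(-c2cnc3[nH]cc(-c4cccc(F)c4)c3c2)cn1` at the top of the three numbers measured in a physicochemical assay for solubility, read by LC-MS, in phosphate buffer, measured as thermodynamic solubility, with a stated time of 24 h, at pH 7.4; on this read-out lower numbers stand for lower solubility and higher numbers for higher solubility: compound 3 gives 3000 nM, and compound 1 gives 3000 nM, a pair that sits within the scatter of one another. Compound 2 `Cn1cc(-c2cnc3[nH]cc(-c4ccc5nonc5c4)c3c2)cn1` gives 300 nM in this assay, a lower number than that of compound 3, a gap that lies beyond the scatter. Going by the values given here, no two of these three compounds differ in a single place, so no single-change step is known among them.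

Compound 4 `Cn1cc(Nc2cnc3[nH]cc(-c4cccc(C#N)c4)c3c2)cn1` is the next compound to be measured. It differs from compound 3 in one place: (1-methyl-1H-pyrazol-4-yl)amino in place of pyrimidin-5-yl on an aromatic carbon. Compound 1 already carries a 1-methyl-1H-pyrazol-4-yl group on the same position of the shared core and gives 3000 nM, so the expected step from compound 3 to compound 4 is no change at the digits printed from compound 3 to compound 4 (within the scatter), a change no larger than the scatter. Compound 4 is therefore estimated at 3000 nM in this assay, with an expected range from 1000 nM to 10000 nM.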

Compound 4, solubility: 31000 nM
Compound 4: the middle estimate sits 10-fold (1.01 log units) below what was measured; the measured number lies above the stated range.
By their numbers in this assay, from the lowest: compound 2; then compounds 1 and 3 (each within the scatter of the next); then compound 4.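

At this aromatic carbon, para to a fused ring, (1-methyl-1H-pyrazol-4-yl)amino in place of pyrimidin-5-yl gives a 10-fold higher number from compound 3 to compound 4 (1.01 log units; beyond the scatter) in this assay. Going by these compounds alone, this is the first reading of a single change here, and it shows that this position can move the number by more than the scatter, which compounds 1 to 3 could not show, as no two of them differ in one place. Within the data shown here, the one step swaps the ring and adds the amino link together, so it cannot assign the rise to either part, and nothing at hand explains it.

The compounds shown leave open whether a bare amine on this carbon would give a comparable step, or whether a pyrazole joined through an ether oxygen would. They also leave open what a morpholine or a piperazine attached at this position would give.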